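Swapping the Ring on a Sulfonamide Nitrogen

This account rests on a few compounds, and the source may have more. Where it says the series, first, only, none or still open, it means among the compounds named here.

In a functional assay on cells (leukaemia cell line, Homo sapiens) for inhibition, read by sulforhodamine B assay, with a stated time of 48 h (on this read-out lower numbers stand for stronger inhibition of growth and higher numbers for weaker inhibition of growth), compound 1 `O=S(=O)(Nc1ccccc1Cl)c1ccc(-c2cnc(C3CC3)o2)cc1` gives 429 nM and compound 2 `O=S(=O)(Nc1ccc(F)cc1F)c1ccc(-c2cnc(C3CC3)o2)cc1` gives 356 nM. Compound 3 `O=S(=O)(Nc1cc(Cl)ccc1Cl)c1ccc(-c2cnc(C3CC3)o2)cc1` stands highest of the three, and so weakest, at 1020 nM. Compound 4 `O=S(=O)(Nc1ccc(I)c(Cl)c1)c1ccc(-c2cnc(C3CC3)o2)cc1` has 3-chloro-4-iodophenyl in place of 2,5-dichlorophenyl on a sulfonamide nitrogen. Two measured steps lead to the group that leaves, a 2.4-fold higher number from compound 1 to compound 3 (0.38 log units; beyond the scatter) and a 2.9-fold higher number from compound 2 to compound 3 (0.46 log units; beyond the scatter), and both are modest, while a 1.2-fold lower number from compound 1 to compound 2 (0.08 log units; within the scatter) stays within the scatter. Losing that group may undo a step of this size, although no compound carrying iodine has been measured. The expected change is modest and toward a lower number, a 1.9-fold lower number from compound 3 to compound 4 (0.27 log units; within the scatter). For compound 4 the estimated value is 550 nM, with an expected range of 170 nM to 1500 nM.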

Compound 4, concentration for 50% growth inhibition: 1010 nM
Compound 4: the middle estimate sits 1.8-fold (0.26 log units) below what was measured; measured number inside the range.
By their numbers in this assay, from the lowest: compounds 2 and 1 (each within the scatter of the next); then compounds 4 and 3 (each within the scatter of the next).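

Putting 3-chloro-4-iodophenyl in place of 2,5-dichlorophenyl on a sulfonamide nitrogen gives a step within the scatter (a 1.0-fold lower number from compound 3 to compound 4 (0.00 log units; within the scatter)), so iodine is tolerated here and compound 3 and compound 4 cannot be told apart. The other two steps (a 2.8-fold higher number from compound 2 to compound 4 (0.45 log units; beyond the scatter)) and (a 2.4-fold higher number from compound 1 to compound 4 (0.37 log units; beyond the scatter)) place compound 4 on the weaker side, so the four compounds form two pairs. Nothing available accounts for this split. From the compounds shown here alone, whether a ring carrying an amine or a carboxylic acid would give a lower number at this nitrogen stays open. So does how a ring bearing iodine alone would compare.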